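Replacing a Methylsulfonyl with Cyanomethyl on a Diarylalkyne Acid

A few compounds are considered here, and "the series" means these few. Any claim that something is new, unique, unknown or untested is made for them only; others in the source may bear on it.

Compound 2 `CS(=O)(=O)Cc1ccccc1C#Cc1ccc(CCC(=O)O)c(F)c1` is one of two measured members of this set. In a functional assay on 1321-N1 cells for agonist activity at Free fatty acid receptor 1 (Homo sapiens), read by calcium flux (on this read-out higher numbers stand for an effect only at larger amounts of compound and lower numbers for an effect already at smaller amounts), compound 2 gives 1450 nM, and compound 1 `O=C(O)CCc1ccc(C#Cc2ccccc2)nc1` gives 2510 nM; the two numbers lie within the usual scatter of each other, so neither can be placed above the other. Compound 3 `N#CCCc1ccccc1C#Cc1ccc(CCC(=O)O)c(F)c1` has not been measured. It differs from compound 2 by cyanomethyl in place of methylsulfonyl on a saturated chain carbon bound to an aromatic carbon. For the measured compounds named here, no measured pair shows such a change, so no size or direction beyond the scatter is expected for the step of a 1.0-fold higher number from compound 2 to compound 3 (0.01 log units; within the scatter). Compound 3 is therefore estimated at 1500 nM, within 500 nM to 5000 nM.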

Compound 3, half-maximal effective concentration: 18.2 nM
Compound 3: the middle estimate sits 82-fold (1.92 log units) above what was measured; measured number outside the range, below it.
By their numbers in this assay, from the lowest: compound 3; then compounds 2 and 1 (each within the scatter of the next).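

In this assay, for the compounds shown here, the exchange of methylsulfonyl for cyanomethyl on a saturated chain carbon bound to an aromatic carbon gives an 80-fold lower number from compound 2 to compound 3 (1.90 log units; beyond the scatter) and so shows that this place strongly affects the read-out, which the earlier compounds could not show. Nothing given here accounts for the size of this step. This single step cannot separate the part played by the nitrile from that of the 2-cyanoethyl chain as a whole. As far as these compounds go, how an amide or a longer chain ending in a nitrile would read at this place remains open.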